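The compounds below may be only part of what the source reports. "The series", "measured", "known", "first", "only" and "open" are said of these compounds alone.

Compound 1, `CCC/N=C(\C)c1c(O)c2ccccc2[nH]c1=O`: >= 100000 nM
Compound 2, `CCC/C(=N\Cc1ccccc1)c1c(O)c2ccccc2oc1=O`: >= 100000 nM

In an assay on isolated protein for inhibition of myosin-2 (Bos taurus), read by spectrophotometry, with a stated time of 24 min (on this read-out lower numbers stand for stronger inhibition and higher numbers for weaker inhibition), compound 1 gives >= 100000 nM, which is a limit of the assay rather than a number. Compound 2 in this assay gives >= 100000 nM, again a limit and not a number. Within the data shown here, compound 1 therefore stands only at a limit, and the one further value shown is a limit too, as both sit at the limit of >= 100000 nM in this assay, at which 2 of the 2 values shown sit. Compound 3 `CCCCC/N=C(\C)c1c(O)c2ccccc2[nH]c1=O` has not yet been measured in this assay. It differs from compound 1 by ethyl in place of hydrogen on a saturated chain carbon, three bonds along the chain from a double-bonded nitrogen. Among the measured compounds shown here, no step between two measured compounds is available, so the effect of lengthening this chain cannot be read from the data; nothing here points in either direction. Because compound 1 gives >= 100000 nM, compound 3 is expected to remain at the limit as well. The step of a number no higher from compound 1 to compound 3 (the limit leaves the size open) is expected to be none beyond the scatter. Compound 3 is estimated at 100000 nM, with a range from 30000 nM to 300000 nM, and is most likely to be reported only as a limit.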

Compound 3, half-maximal inhibitory concentration: >= 100000 nM
Compound 3 ended at the assay's limit (the forecaster's own chance of this, stated with the estimate: 80%); the middle value sits exactly at the limit.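

The step from compound 1 to compound 3 cannot be read in this assay, because both compounds stand only at a limit there: the limit of >= 100000 nM in this assay, at which 3 of the 3 values shown sit. The compounds shown leave open whether any change to the chain or to the shared core would bring a value inside the measurable range of this assay.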